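Lengthening the chain of compound 2

This account rests on a few compounds, and the source may have more. Where it says the series, first, only, none or still open, it means among the compounds named here.

Compound 2 `O=C(CCCNC(=O)c1cc(-c2ccc(F)cc2)[nH]n1)NO` gives 1060 nM in an assay on cells for inhibition of protein deacetylase HDAC6 (Homo sapiens), read by fluorescence, with stated times of 15 min and 60 min (on this read-out lower numbers stand for stronger inhibition and higher numbers for weaker inhibition), the highest of the three numbers seen so far. Compound 1 `Cc1cc(-c2ccc(F)cc2)n(Cc2ccc(C(=O)NO)cc2)n1` gives 20 nM and compound 3 `CCc1cc(-c2ccc(F)cc2)n(Cc2ccc(C(=O)NO)cc2)n1` gives 69 nM; both carry the hydroxamic acid on a ring attached to the core, whereas compound 2 carries it at the end of a chain. Among the compounds with values here, the only measured step, a 3.5-fold higher number from compound 1 to compound 3 (0.54 log units; beyond the scatter), concerns the core itself and does not bear on chain length. Compound 4 `O=C(CCCCCNC(=O)c1cc(-c2ccc(F)cc2)[nH]n1)NO` differs from compound 2 by 2-(hydroxycarbamoyl)ethyl in place of hydroxycarbamoyl on a saturated chain carbon, three bonds along the chain from an amide-type nitrogen. Within the data shown here, no measured pair covers this kind of change, so the expectation rests on the structures alone and is uncertain. Compound 4 is expected to give about 300 nM, somewhere between 60 nM and 1500 nM, which would mean a step of a 3.5-fold lower number from compound 2 to compound 4 (0.55 log units; beyond the scatter).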

Compound 4, half-maximal inhibitory concentration: 29 nM
Compound 4: middle estimate off by 10-fold (1.01 log units), on the high side, and the stated range ends above it.
By their numbers in this assay, from the lowest: compounds 1 and 4 (each within the scatter of the next); then compound 3; then compound 2.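

Replacing hydroxycarbamoyl with 2-(hydroxycarbamoyl)ethyl on this saturated chain carbon gives a large change in this assay, a 37-fold lower number from compound 2 to compound 4 (1.56 log units; beyond the scatter). Chain length at this position therefore matters strongly, which the earlier compounds, with their single step on the core, could not show. Nothing available here explains why the number falls.

Two chain lengths alone do not show whether a still longer chain would lower the number further or raise it again. Going by these compounds, it also stays open how the chain would fare with a carboxylic acid at its end in place of the hydroxycarbamoyl group.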